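The compounds below may be only part of what the source reports. "The series", "measured", "known", "first", "only" and "open" are said of these compounds alone.

Measured so far:
compound 1 `Cc1ccc(-c2nc(N)c3nc(-c4ccccc4)sc3n2)o1`, in an assay on CHO cells for displacement of a labelled ligand from adenosine receptor A3 (Homo sapiens), read by scintillation counting, with a stated time of 3 h (on this read-out higher numbers stand for weaker inhibition and lower numbers for stronger inhibition), compound 1 gives 24.9 nM
compound 2 `Nc1nc(-c2ccco2)nc2sc(-c3ccco3)nc12`, in this assay compound 2 gives 99 nM

Compound 2 stands highest of the two numbers; the nearest is compound 1, whose number is lower by a gap beyond the usual scatter.

Compound 3 `Cc1ccc(-c2nc(N)c3nc(-c4ccco4)sc3n2)o1` is not yet measured. Compared with compound 2 the change is methyl in place of hydrogen on an aromatic carbon. Among the compounds with values here, no measured pair shows this step on its own. Compound 1 carries the same 5-methylfuran-2-yl and gives the lower number, so a modest move toward a lower number is expected, possibly no larger than the scatter. The step from compound 2 to compound 3 is estimated at a 1.8-fold lower number from compound 2 to compound 3 (0.26 log units; within the scatter). Compound 3 is expected to give 55 nM, within 22 nM to 140 nM.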

Compound 3, inhibition constant: 13.8 nM
The estimate for compound 3 lay 4.0-fold (0.60 log units) above the measured number; measured number outside the range, below it.
By their numbers in this assay, from the lowest: compounds 3 and 1 (each within the scatter of the next); then compound 2.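

In this assay, within the data shown here, furan-2-yl to 5-methylfuran-2-yl, seen on its own for the first time, gives a 7.2-fold lower number from compound 2 to compound 3 (0.86 log units; beyond the scatter) and so shows that this methyl, next to the ring oxygen, matters at this position. At the other aromatic position, furan-2-yl in place of phenyl gives a 1.8-fold lower number from compound 1 to compound 3 (0.26 log units; within the scatter) and does not separate the two groups while the 5-methylfuran-2-yl stays in place. Nothing shown accounts for the methyl step.

Open, as far as these compounds go, is whether an ethyl chain, a chlorine or an amine in place of this methyl would keep the step.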